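Replacing a Nitro Group with a Pyridinyloxy Ether

The source may hold more compounds than are shown below. What is called first, only, known or untested is meant among the compounds shown, and "the series" means these compounds.

Three compounds share a common core and were measured in a functional assay with metabotropic glutamate receptor 5 (Rattus norvegicus) as the target; a lower number here means a stronger inhibitor, a higher number a weaker inhibitor. Compound 1 `N#Cc1cccc(-n2nnc(-c3ccccn3)n2)c1` gives 73 nM. Compound 2 `N#Cc1cc(-n2nnc(-c3ccccn3)n2)cc([N+](=O)[O-])c1` gives 42 nM, which is the second lowest of the three numbers. Compound 3 `COc1cc(C#N)cc(-n2nnc(-c3ccccn3)n2)c1` gives 10 nM. The step of a 1.7-fold lower number from compound 1 to compound 2 (0.24 log units; within the scatter) is within the scatter, whereas a 7.3-fold lower number from compound 1 to compound 3 (0.86 log units; beyond the scatter) and a 4.2-fold lower number from compound 2 to compound 3 (0.62 log units; beyond the scatter) are modest but real gains.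

Compound 4 `N#Cc1cc(Oc2cccnc2)cc(-n2nnc(-c3ccccn3)n2)c1` differs from compound 2 in one place: (pyridin-3-yl)oxy in place of nitro on an aromatic carbon. For the measured compounds named here, the steps that bear on this are a 4.2-fold lower number from compound 2 to compound 3 (0.62 log units; beyond the scatter), where an oxygen-linked group replaced the same nitro, and a 7.3-fold lower number from compound 1 to compound 3 (0.86 log units; beyond the scatter), where that oxygen-linked group replaced hydrogen. Going by the values given here, the entering (pyridin-3-yl)oxy group is considerably larger than methoxy, and no measured compound shows how a group of that size behaves at this position, so the precedent is only partial.

Compound 4 is therefore expected to give a somewhat lower number than compound 2, with the step of a 1.7-fold lower number from compound 2 to compound 4 (0.23 log units; within the scatter) likely smaller than the methoxy case. The estimate for compound 4 in this assay is 25 nM, with a range from 8 nM to 80 nM.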

Compound 4, half-maximal inhibitory concentration: 15 nM
Compound 4: the middle estimate sits 1.7-fold (0.22 log units) above what was measured; low and high end bracket the measured number.
By their numbers in this assay, from the lowest: compounds 3 and 4 (each within the scatter of the next); then compounds 2 and 1 (each within the scatter of the next).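

In this assay the place meta to a cyano group accepts far more than methoxy: (pyridin-3-yl)oxy, which brings one six-membered aromatic ring on its oxygen, gives a 2.8-fold lower number from compound 2 to compound 4 (0.45 log units; beyond the scatter) and a 4.9-fold lower number from compound 1 to compound 4 (0.69 log units; beyond the scatter) so the gain over nitro and over hydrogen is not limited to the small methoxy group. Exchanging the methyl on that oxygen for pyridin-3-yl gives a 1.5-fold higher number from compound 3 to compound 4 (0.18 log units; within the scatter) and so, despite the difference in size, the two oxygen-linked groups cannot be told apart in this assay. Nothing shown gives a reason for this tolerance.

The compounds shown leave open whether the ring nitrogen of the pyridin-3-yl group matters, which a phenoxy group in the same place would test, and whether the oxygen link is needed, which an amine or methylene link would test. They also leave open how far this place can be extended, for instance with a longer alkoxy chain or a benzyloxy group, and whether it accepts a carboxylic acid or an amide.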